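A few compounds are considered here, and "the series" means these few. Any claim that something is new, unique, unknown or untested is made for them only; others in the source may bear on it.

Measured compounds:
Compound 1 `CCn1cc(-c2nc3ccccc3s2)c(=O)c2cc(F)c(N3CCNCC3)cc21`, in a functional assay on KB cells (Homo sapiens) for cytotoxicity, read by MTT assay, with a stated time of 48 h (a higher number here means a weaker inhibitor, a lower number a stronger inhibitor), compound 1 gives 28700 nM.
Compound 2 `CCn1cc(-c2nc3ccccc3s2)c(=O)c2cc(F)c(N3CCNCC3)nc21`, compound 2 gives 2400 nM.
Compound 3 `CCn1cc(-c2nc3ccc(Cl)cc3[nH]2)c(=O)c2cc(F)c(N3CCNCC3)nc21`, compound 3 gives 10300 nM.

Compound 1 has the highest number of the three; compound 2 and compound 1 share a related core, but the difference between the two cores is not broken down here. Within the core of compound 2, one change has been measured: 6-chloro-1H-benzimidazol-2-yl in place of 1,3-benzothiazol-2-yl on an aromatic carbon, which gave a 4.3-fold higher number from compound 2 to compound 3 (0.63 log units; beyond the scatter). The unmeasured compound 4 `CCn1cc(-c2nc3ccc(Cl)cc3[nH]2)c(=O)c2cc(F)c(N3CCNCC3)cc21` carries the same change on the core of compound 1, (6-chloro-1H-benzimidazol-2-yl in place of 1,3-benzothiazol-2-yl on an aromatic carbon), at a place described in the same words, so it is the same change. Among the measured compounds shown here, compound 4 is therefore expected to give a step of about a 3.5-fold higher number from compound 1 to compound 4 (0.54 log units; beyond the scatter), resting on the single measured step from compound 2 to compound 3, so the expectation is loosely held. Compound 4 is estimated at 100000 nM, between 40000 nM and 250000 nM.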

Compound 4, half-maximal inhibitory concentration: 1600 nM
Compound 4: middle estimate off by 63-fold (1.80 log units), on the high side, outside the stated range (below it).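

In this assay, putting 6-chloro-1H-benzimidazol-2-yl in place of 1,3-benzothiazol-2-yl gave an 18-fold lower number from compound 1 to compound 4 (1.25 log units; beyond the scatter). The same change therefore did not carry over from one core to the other, and its direction reversed: the same change on two cores in this assay, a 4.3-fold higher number (0.63 log units; beyond the scatter) from compound 2 to compound 3 and an 18-fold lower number (1.25 log units; beyond the scatter) from compound 1 to compound 4, 77-fold (1.89 log units) apart, beyond the scatter of two such steps This shows that in these two pairs the outcome of the change depends on the core that carries it, but it does not show which difference between the cores is responsible, and two pairs set no rule for any other core.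

The compounds shown leave open whether the chlorine or the benzimidazole itself drives the reversal, which an unsubstituted 1H-benzimidazol-2-yl group could separate. They also leave open whether the reversal persists with a longer chain in place of the ethyl group.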